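The source may hold more compounds than are shown below. What is called first, only, known or untested is meant among the compounds shown, and "the series" means these compounds.

Values in a functional assay on MDA-MB-231 cells (Homo sapiens) for antiproliferative activity, read by sulforhodamine B assay, with a stated time of 48 h (a higher number here means a weaker inhibitor, a lower number a stronger inhibitor), so far:
Compound 1 `COc1ccc(C(=O)/C=C\Nc2ccc(-c3nc4cc(OC)c(OC)c(OC)c4s3)cc2C)cc1O` gives 12400 nM
Compound 2 `COc1cc(C(=O)/C=C\Nc2ccc(-c3nc4cc(OC)c(OC)c(OC)c4s3)cc2C)cc([N+](=O)[O-])c1OC` gives 12800 nM
Compound 3 `COc1ccc2nc(-c3ccc(N/C=C\C(=O)c4cc(OC)c(OC)c(OC)c4)c(C)c3)sc2c1` gives 17000 nM

These three values all lie within the usual scatter of one another. Compound 2 therefore stands inside a tight group, and its value cannot be told apart from those of compound 1 and compound 3.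

Compound 4 `COc1ccc(C(=O)/C=C\Nc2ccc(-c3nc4cc(OC)c(OC)c(OC)c4s3)cc2C)cc1[N+](=O)[O-]` is compound 2 with a single change (hydrogen in place of methoxy on an aromatic carbon): hydrogen in place of methoxy on an aromatic carbon. Among the measured compounds shown here, no two measured compounds differ in one place only, so the size of such a change has not been seen directly. Even so, compound 1 at 12400 nM and compound 3 at 17000 nM differ from compound 2 in more than one place, and their values stay within the scatter of its value. In this assay the expectation is therefore no step beyond the scatter, in either direction.

The expected change is a 1.1-fold lower number from compound 2 to compound 4 (0.03 log units; within the scatter) and this estimate counts as no real shift. For compound 4 the estimated value is 12000 nM with an expected range from 5000 nM to 30000 nM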

Compound 4, half-maximal inhibitory concentration: 12400 nM
For compound 4 the middle estimate is 1.0-fold (0.01 log units) below the measured one; measured number inside the range.
By their numbers in this assay, from the lowest: compounds 1, 4, 2 and 3 (each within the scatter of the next).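

In this assay, among the compounds shown here, single-place comparisons can now be read for the first time, and hydrogen in place of methoxy, on an aromatic carbon ortho to a methoxy group and meta to a nitro group, gives a 1.0-fold lower number from compound 2 to compound 4 (0.01 log units; within the scatter). Nitro in place of hydroxy on an aromatic carbon gives no change at the digits printed from compound 1 to compound 4 (within the scatter). Neither step lies beyond the scatter, so at these places methoxy, hydrogen, nitro and hydroxy cannot be told apart in this read-out, and no supporting data are available to explain this.

Going by these compounds, it remains open whether an amine or a carboxylic acid on these aromatic carbons, or a longer chain in place of methoxy, would give a step beyond the scatter. On these data alone, it is also open whether these two steps would look the same in a different assay.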